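A few compounds are considered here, and "the series" means these few. Any claim that something is new, unique, unknown or untested is made for them only; others in the source may bear on it.

In a physicochemical assay for lipophilicity (on this read-out lower numbers stand for lower lipophilicity and higher numbers for higher lipophilicity), compound 1 `C/C=C/C=C/C(=O)NCC` gives 1.19, compound 2 `C/C=C/C=C/C(=O)NN` gives 0.59 and compound 3 `C/C=C/C=C/C(=O)OCC` gives 1.84. Compound 3 thus has the highest number of the three and stands clear of both others, with a number 0.65 log units higher from compound 1 to compound 3 (beyond the scatter) and a number 1.25 log units higher from compound 2 to compound 3 (beyond the scatter).

The next compound is compound 4 `C/C=C/C=C/C(=O)OCCC`. It differs from compound 3 by methyl in place of hydrogen on a saturated chain carbon, two bonds along the chain from an oxygen next to a carbonyl group, which reads as ethyl to propyl when cut one bond further out.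

For the measured compounds named here, no measured step is this same exchange. The closest guide is a number 0.60 log units lower from compound 1 to compound 2 (beyond the scatter), where amino takes the place of ethyl on an amide-type nitrogen, so a chain is lost at a different atom. The two steps ending at compound 3 swap the whole group on the carbonyl carbon and bear on the new change less directly. They mainly show how far this short series spreads in this assay.

A modest upward move is therefore expected, with the expected step being a number 0.46 log units higher from compound 3 to compound 4 (beyond the scatter). For compound 4 the estimated value is 2.3, with an expected range of 2.05 to 2.6.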

Compound 4, partition coefficient: 2.31
Compound 4: middle estimate off by 0.01 log units, on the low side, within the range that was stated.
By their numbers in this assay, from the lowest: compound 2; then compound 1; then compound 3; then compound 4.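

In this assay, for the compounds shown here, the exchange of ethyl to propyl gives a number 0.47 log units higher from compound 3 to compound 4 (beyond the scatter) and is the first step that changes only a saturated chain, by methyl in place of hydrogen on a saturated chain carbon, two bonds along the chain from an oxygen next to a carbonyl group. The earlier steps shown here exchanged a group on an amide-type nitrogen or the whole group on a carbonyl carbon, so they gave no separate reading of this chain carbon, whereas this position has now taken a methyl with a change beyond the scatter. Nothing available here explains the size of this step.

A single step on one chain leaves open whether butyl or a longer chain would continue the rise, and whether a branched group such as isopropyl would read like propyl. It also leaves open whether ethyl to propyl on the amide-type nitrogen of compound 1 would give a similar step, and how a hydroxyl or an amine in place of the added methyl would read.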